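Piperidin-1-yl to Morpholin-4-yl on a Thiocarbonyl Carbon

The source may hold more compounds than are shown below. What is called first, only, known or untested is meant among the compounds shown, and "the series" means these compounds.

Measured so far:
compound 1, `Cc1ccc2c(=O)c(CSC(=S)N3CCCCC3)coc2c1`, 5100 nM
compound 2, `CC(C)N(C(=S)SCc1cc(=O)c2ccc(Cl)cc2o1)C(C)C`, > 30000 nM (a limit of the assay, not a number)

Of the compounds shown here, two sharing the same core have been tested in a functional assay on LM7 cells (Homo sapiens) for antiproliferative activity, read by MTT assay, with a stated time of 72 h; a higher number here means a weaker inhibitor, a lower number a stronger inhibitor. Compound 1 gives 5100 nM. Compound 2 returns only > 30000 nM, which is a limit of the assay rather than a number. Within the data shown here, compound 1 therefore stands as the only real number in this assay; the other entry is the limit of > 30000 nM in this assay, at which 1 of the 2 values shown sits. Among the measured compounds shown here, no pair of measured compounds differs in just one place, so no measured step is available as a guide.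

Compound 3, `Cc1ccc2c(=O)c(CSC(=S)N3CCOCC3)coc2c1`, has not yet been measured. It differs from compound 1 by morpholin-4-yl in place of piperidin-1-yl on a thiocarbonyl carbon. For the measured compounds named here, with no measured step to lean on, the expectation in this assay is a small step, if any, more likely toward a weaker value than a stronger one, and possibly none beyond the usual scatter.

Compound 3 is expected to give about 8000 nM, with a likely range from 3000 nM to 25000 nM. The step of a 1.6-fold higher number from compound 1 to compound 3 (0.20 log units; within the scatter) is thus expected to be modest.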

Compound 3, half-maximal inhibitory concentration: 14300 nM
Estimate against measurement, compound 3: 1.8-fold (0.25 log units) below; measured number inside the range.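

In this assay, the change of piperidin-1-yl to morpholin-4-yl on a thiocarbonyl carbon gives a 2.8-fold higher number from compound 1 to compound 3 (0.45 log units; beyond the scatter). Among these compounds, this is the first measured change at a single place in this set, and it shows that the group on the thiocarbonyl carbon is not a silent spot: both groups are six-membered non-aromatic rings of 6 heavy atoms, yet replacing one ring carbon with an oxygen, which adds 1 hydrogen-bond acceptor, is enough to give a weaker inhibitor. Compound 2 differs from compound 1 in more than one place, so it says nothing about this step, and its entry is a limit of the assay, not a number: the limit of > 30000 nM in this assay, at which 1 of the 3 values shown sits.

One pair cannot separate the effect of the oxygen itself from that of simply having a different ring, and the data give no reason for the step. A piperazin-1-yl group, with a second ring nitrogen in place of the oxygen, or an open-chain amine such as diethylamino on the same carbon would show whether the piperidin-1-yl ring of compound 1 is the better choice in general or only better than morpholin-4-yl.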